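Aryl replacement on the fused core: expectation for compound 4

A few compounds are considered here, and "the series" means these few. Any claim that something is new, unique, unknown or untested is made for them only; others in the source may bear on it.

Three analogues share one core and differ only in the aryl group on the five-membered ring. Compound 1 `COc1ccc(-c2cc3nccc(-c4cc(OC)c(OC)c(OC)c4)n3n2)cc1N` gives 27 nM in a functional assay on MCF7 cells (Homo sapiens) for inhibition, read by CCK-8 assay, with a stated time of 48 h (a lower number here means a stronger inhibitor, a higher number a weaker inhibitor), and stands lowest of the three numbers. Compound 2 `COc1cc(-c2ccnc3cc(-c4ccc(C(C)=O)cc4)nn23)cc(OC)c1OC` gives 5230 nM, and compound 3 `COc1cc(-c2ccnc3cc(-c4c[nH]c5ccccc45)nn23)cc(OC)c1OC` gives 85 nM. The step of a 190-fold higher number from compound 1 to compound 2 (2.29 log units; beyond the scatter) is large, whereas a 3.1-fold higher number from compound 1 to compound 3 (0.50 log units; beyond the scatter) is modest; between those two, a 62-fold lower number from compound 2 to compound 3 (1.79 log units; beyond the scatter) recovers most of the loss.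

Compound 4 `COc1cc(-c2ccnc3cc(-c4ccc(F)cc4)nn23)cc(OC)c1OC` carries the change (4-fluorophenyl in place of 3-amino-4-methoxyphenyl on an aromatic carbon). Both measured steps from compound 1 bear on it, since each removes the 3-amino-4-methoxyphenyl: putting in 4-acetylphenyl, a 190-fold higher number from compound 1 to compound 2 (2.29 log units; beyond the scatter), cost far more than putting in 1H-indol-3-yl, a 3.1-fold higher number from compound 1 to compound 3 (0.50 log units; beyond the scatter). The 4-fluorophenyl brings no hydrogen-bond donor and no acceptor, so a rise well beyond the scatter is expected in this assay, though a rise as steep as that seen for compound 2 is not assumed. For compound 4 the expected step is a 30-fold higher number from compound 1 to compound 4 (1.47 log units; beyond the scatter). The estimate for compound 4 is 800 nM, within a range of 150 nM to 4000 nM.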

Compound 4, half-maximal inhibitory concentration: 1280 nM
The estimate for compound 4 lay 1.6-fold (0.20 log units) below the measured number, within the range that was stated.
By their numbers in this assay, from the lowest: compound 1; then compound 3; then compound 4; then compound 2.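

In this assay, 4-fluorophenyl on this aromatic carbon gives a 47-fold higher number from compound 1 to compound 4 (1.68 log units; beyond the scatter) and a 15-fold higher number from compound 3 to compound 4 (1.18 log units; beyond the scatter), so a large loss at this position is not confined to 4-acetylphenyl. Fluoro in place of acetyl gives a 4.1-fold lower number from compound 2 to compound 4 (0.61 log units; beyond the scatter), a modest recovery that leaves both compound 2 and compound 4 far from compound 1 and compound 3. No measurement shown accounts for this order.

Going by these compounds, how much of the advantage of 3-amino-4-methoxyphenyl rests on its amino group and how much on its methoxy group remains open, as neither is varied alone here. A hydroxyl group in place of that amino group, or a phenyl ring bearing only the amine, would separate the two contributions.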